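Fluoro for Methyl on the Amide-Bound Ring

The compounds below may be only part of what the source reports. "The series", "measured", "known", "first", "only" and "open" are said of these compounds alone.

Going by the values given here, the three compounds measured so far share one core and differ only in the groups carried on the aromatic ring attached to the amide. Compound 1 `CCN1CCc2c(c(C)nn2C(=O)Nc2cc(C)ccc2C)C1` gives, in a functional assay on the whole organism (strain Swiss albino) for inhibition, with Mus musculus as the target, in the writhing test, with a stated time of 30 min, at a dose of 100 mg/kg (on this read-out higher numbers stand for more inhibition at the one dose given (going by the name of the read-out) and lower numbers for less inhibition), a value of 62.2%, which is the second highest of the three numbers. Compound 2 `CCN1CCc2c(c(C)nn2C(=O)Nc2ccc(C)cc2C)C1` gives 56.1%, a number within the usual scatter of that of compound 1. Compound 3 `CCN1CCc2c(c(C)nn2C(=O)Nc2ccc(F)cc2F)C1`, which carries fluoro groups where the other two carry methyl groups, gives 76.3%, a number beyond the scatter above that of compound 1.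

Compound 4 `CCN1CCc2c(c(C)nn2C(=O)Nc2cc(C)ccc2F)C1` is not yet measured. It is reached from compound 1 by one change: fluoro in place of methyl on an aromatic carbon. Because compound 3 with its fluoro groups gives 76.3%, a modest rise is expected, so the step of a number 5.8 percentage points higher from compound 1 to compound 4 (within the scatter) is expected to be small and upward, possibly within the scatter. Compound 4 is therefore estimated to give 68%, with a range from 55% to 80%.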

Compound 4, a percentage reported as inhibition, in the whole organism at one dose (the size of the read-out at that dose, not a potency): 10.5%
Compound 4: middle estimate off by 57.5 percentage points, on the high side, and the stated range ends above it.
By their numbers in this assay, from the lowest: compound 4; then compounds 2 and 1 (each within the scatter of the next); then compound 3.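

Going by these compounds alone, until now, no two measured compounds differed in only one place, so no single change could be read on its own. In this assay fluoro in place of methyl on the aromatic carbon ortho to a large group and para to a methyl group brings a number 51.7 percentage points lower from compound 1 to compound 4 (beyond the scatter) and so shows that the read-out can depend heavily on which of these two groups occupies this one position, even though the change swaps only one heavy atom for another. Nothing available gives a reason for this fall.

On these data alone, whether the fall reflects the arrival of fluoro or the loss of methyl stays open, as does the outcome with other groups here, such as chloro, methoxy or an amine. Also open, as far as these compounds go, is whether the other methyl group of compound 1 would respond in the same way to fluoro.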